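From Ethyl to Isopentyl at the Assay Limit

This account rests on a few compounds, and the source may have more. Where it says the series, first, only, none or still open, it means among the compounds named here.

Measured so far in a functional assay on SK-BR-3 cells (Homo sapiens) for antiproliferative activity, read by MTT assay, with a stated time of 72 h (a higher number here means a weaker inhibitor, a lower number a stronger inhibitor), as limits, not numbers:
Compound 1 `C/C=C1/[C@H](O[C@@H]2O[C@H](CO)[C@@H](O)[C@H](O)[C@H]2O)OC=C(C(=O)OC)[C@H]1CC(=O)OCc1ccco1` gives > 15000 nM as a limit
Compound 2 `C#CCOC(=O)C[C@@H]1C(C(=O)OC)=CO[C@@H](O[C@@H]2O[C@H](CO)[C@@H](O)[C@H](O)[C@H]2O)/C1=C/C` gives > 15000 nM as a limit
Compound 3 `C/C=C1/[C@H](O[C@@H]2O[C@H](CO)[C@@H](O)[C@H](O)[C@H]2O)OC=C(C(=O)OC)[C@H]1CC(=O)OCC` gives > 15000 nM as a limit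

In this assay compound 3 stands at > 15000 nM as a limit, not a number. The set as a whole shows the limit of > 15000 nM in this assay, at which 3 of the 3 values shown sit, and so offers no ranking of the three compounds.

Compound 4 `C/C=C1/[C@H](O[C@@H]2O[C@H](CO)[C@@H](O)[C@H](O)[C@H]2O)OC=C(C(=O)OC)[C@H]1CC(=O)OCCC(C)C` differs from compound 3 by isopropyl in place of hydrogen on a saturated chain carbon, two bonds along the chain from an oxygen next to a carbonyl group and the same difference, cut one bond further out, reads ethyl to isopentyl. For the measured compounds named here, two measured steps bear on this chain, a step that the two limits leave unreadable from compound 1 to compound 3 and a step that the two limits leave unreadable from compound 2 to compound 3, and neither has a size that can be read. They set no direction for the new change. With compound 3 at > 15000 nM as its starting limit, nothing measured points to a gain. The step that the limit leaves unreadable from compound 3 to compound 4 is therefore expected to stay within the scatter, with no direction favoured. In this assay compound 4 is estimated at 22000 nM with a range from 8000 nM to 60000 nM expected, and it will most likely be reported as a limit again.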

Compound 4, half-maximal inhibitory concentration: 9020 nM
Estimate against measurement, compound 4: 2.4-fold (0.39 log units) above; measured number inside the range.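

In this assay compound 4 gives 9020 nM. The isopentyl ester is thus the only one here that returns a number rather than a limit, and a change on a saturated chain carbon, two bonds along the chain from an oxygen next to a carbonyl group, can leave the assay limit. Measured against the three limits, this gives an at least 1.6-fold lower number from compound 3 to compound 4 (0.22 log units; that floor lies within the scatter), an at least 1.6-fold lower number from compound 2 to compound 4 (0.22 log units; that floor lies within the scatter) and an at least 1.6-fold lower number from compound 1 to compound 4 (0.22 log units; that floor lies within the scatter); each is only a floor, so none of them establishes a real gain for compound 4 over the other compounds. The steps among compound 1, compound 2 and compound 3 cannot be read, and these compounds remain limits, so the set still has a single number and no ranking: the limit of > 15000 nM in this assay, at which 3 of the 4 values shown sit.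

Going by these compounds, the true size of the steps to compound 4 stays open, as does any trend with chain shape or length, since one number cannot define one. Also open, on these data alone, is whether a longer chain than isopentyl, or an amine or a carboxylic acid in its place, would give a number in this assay, and on which side of the value of compound 4 it would fall.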